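A few compounds are considered here, and "the series" means these few. Any claim that something is new, unique, unknown or untested is made for them only; others in the source may bear on it.

In an ADME assay (liver, Mus musculus) for metabolic stability, using microsomes (a higher number here means that the compound lasts longer, a lower number that the compound disappears faster), compound 1 (`CC(C)N(C(=O)n1cnc(S[C@@H]2C[C@H]3CC[C@@H]2C3)n1)C(C)C`) gives < 0.0834 h, which is a limit of the assay and not a number. Compound 2 (`O=C(N1CCCC1)n1cnc(S(=O)(=O)[C@@H]2C[C@H]3CC[C@@H]2C3)n1`) likewise gives only a limit, < 0.0834 h. Compound 1 therefore has no exact half-life, and the evidence so far is the limit of < 0.0834 h in this assay, at which 2 of the 2 values shown sit. Compound 3 (`O=C(N1CCCC1)n1cnc(S[C@@H]2C[C@H]3CC[C@@H]2C3)n1`) has pyrrolidin-1-yl in place of diisopropylamino on a carbonyl carbon. Given the limit of < 0.0834 h in this assay, at which 2 of the 2 values shown sit, for compound 1 and compound 2, the expected step that the limit leaves unreadable from compound 1 to compound 3 is none beyond the usual scatter, in either direction. For compound 3, the estimated half-life is 0.08 h, with an expected range from 0.04 h to 0.17 h.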

Compound 3, half-life: < 0.0834 h
Compound 3: only a limit was reported (the forecaster's own chance of this, stated with the estimate: 70%); the middle value is on the limit's open side.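

Within the data shown here, compound 1 and compound 3 both give only a limit in this assay, not a number, so no step between them can be read. The actual half-lives of all three compounds remain open: the limit of < 0.0834 h in this assay, at which 3 of the 3 values shown sit.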